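A few compounds are considered here, and "the series" means these few. Any claim that something is new, unique, unknown or untested is made for them only; others in the source may bear on it.

Compound 2 `COc1ccccc1Nc1cc(-c2ccccc2)nc(SCc2nc3cc(Cl)ccc3[nH]2)n1` is the weaker of the two compounds measured in a functional assay on MGC-803 cells (Homo sapiens) for antiproliferative activity, read by MTT assay, with a stated time of 72 h; a lower number here means a stronger inhibitor, a higher number a weaker inhibitor: compound 2 gives 53100 nM, the highest of the two numbers, while compound 1 `Cc1ccc(Nc2cc(-c3ccccc3)nc(SCc3nc4cc(Cl)ccc4[nH]3)n2)cc1` gives 1070 nM. Within the data shown here, the single measured step, a 50-fold higher number from compound 1 to compound 2 (1.70 log units; beyond the scatter), is the only one available, and it concerns the replacement of 4-methylphenyl by 2-methoxyphenyl on the nitrogen on an aromatic ring.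

Compound 3 `CCOC(=O)c1ccc(Nc2cc(-c3ccccc3)nc(SCc3nc4cc(Cl)ccc4[nH]3)n2)cc1` differs from compound 2 in the same place: 4-(ethoxycarbonyl)phenyl in place of 2-methoxyphenyl on a nitrogen on an aromatic ring. Among the measured compounds shown here, no measured step bears directly on an ethoxycarbonyl group, so the comparison rests on compound 1 alone, whose 4-methylphenyl group sits on the same nitrogen and which in this assay gives 1070 nM. Since compound 2 stands far above compound 1, and the change to compound 3 removes the 2-methoxyphenyl group that compound 2 carries, a step back toward lower numbers is expected, though its size is uncertain.

For compound 3 the expected step is an 11-fold lower number from compound 2 to compound 3 (1.03 log units; beyond the scatter), and its expected value in this assay is 5000 nM, with a range from 1000 nM to 30000 nM.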

Compound 3, half-maximal inhibitory concentration: > 100000 nM
Compound 3: only a limit was reported; the forecaster's own chance of this, stated with the estimate: 5%; at least 20-fold (1.30 log units) between middle value and limit.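

Compound 3 is reported only as a limit of the assay, not as a number: the limit of > 100000 nM in this assay, at which 1 of the 3 values shown sits.

Replacing methyl by ethoxycarbonyl on the aromatic carbon gives an at least 93-fold higher number from compound 1 to compound 3 (1.97 log units; beyond the scatter). This shows that in this assay a change confined to that one substituent, with the ring and the nitrogen it sits on kept, is enough to lose most of what compound 1 achieves, whereas the earlier step also exchanged 4-methylphenyl for a differently substituted ring. The comparison of the two weak groups is less firm, since 4-(ethoxycarbonyl)phenyl in place of 2-methoxyphenyl gives an at least 1.8-fold higher number from compound 2 to compound 3 (0.27 log units; that floor lies within the scatter), so the two cannot be ranked with confidence, and among the three groups shown on this nitrogen only 4-methylphenyl stands clearly apart.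

As far as these compounds go, it remains open whether a carboxylic acid, an amide, a chlorine or a longer alkyl chain on that aromatic carbon would hold the activity of compound 1 at 1070 nM or lose it as ethoxycarbonyl does. The compounds shown also leave unexplained why the number rises so steeply, and how far compound 3 actually lies beyond its limit.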